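Acetamido for methyl on the sulfonyl aryl of compound 3

The source may hold more compounds than are shown below. What is called first, only, known or untested is meant among the compounds shown, and "the series" means these compounds.

Working notes on the series. Of the compounds shown here, three have been measured in a functional assay on SMMC-7721 cells (Homo sapiens) for cytotoxicity, read by MTT assay, with a stated time of 24 h; a higher number here means a weaker inhibitor, a lower number a stronger inhibitor. Compound 1 `N#Cc1ccc(S(=O)(=O)N2C/C(=C\c3ccccc3F)C(=O)/C(=C/c3ccccc3F)C2)cc1` gives 14600 nM. Compound 2 `O=C1/C(=C/c2cccc(F)c2)CN(S(=O)(=O)c2ccccc2)C/C1=C\c1cccc(F)c1` gives 12900 nM in this assay. Compound 3 `Cc1ccc(S(=O)(=O)N2C/C(=C\c3ccc(F)cc3)C(=O)/C(=C/c3ccc(F)cc3)C2)cc1` gives 5000 nM in this assay, the lowest of the three numbers; its gaps to compound 2 and to compound 1 both lie beyond the scatter, so compound 3 is the strongest inhibitor of the three. No pair of these compounds differs in one place only, so nothing among them isolates a single substituent change, and the three also carry fluorine at different places on their benzylidene rings.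

Compound 4 `CC(=O)Nc1ccc(S(=O)(=O)N2C/C(=C\c3ccc(F)cc3)C(=O)/C(=C/c3ccc(F)cc3)C2)cc1` is not yet measured. It differs from compound 3 as follows: acetamido in place of methyl on an aromatic carbon. Among the compounds with values here, no step of this kind has been measured, so the expectation rests on compound 3 alone. A modest step is expected in this assay, if any, toward a somewhat higher number. The expected step is a 1.4-fold higher number from compound 3 to compound 4 (0.15 log units; within the scatter), and it may well fall within the scatter. Compound 4 is accordingly estimated at 7000 nM, with a range from 2500 nM to 20000 nM.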

Compound 4, half-maximal inhibitory concentration: 9800 nM
Estimate against measurement, compound 4: 1.4-fold (0.15 log units) below; the measured number falls inside the stated range.
By their numbers in this assay, from the lowest: compounds 3, 4, 2 and 1 (each within the scatter of the next, the first and the last beyond it).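

This pair gives the series its first reading of one place alone: with the shared core and the fluorine positions held constant, 4-methylphenyl gives way to 4-acetamidophenyl on the sulfonyl side. In this assay the change reads as a 2.0-fold higher number from compound 3 to compound 4 (0.29 log units; within the scatter) and so separates the two compounds by no more than repeated measurements would, even though acetamido is the larger group and, unlike methyl, carries a hydrogen-bond donor and a hydrogen-bond acceptor. For this pair, then, those added atoms at this aromatic carbon leave the cytotoxicity reading indistinguishable, and no measurement on hand speaks to why the two groups read alike.

Still open, on these data alone, is whether this holds for groups of another kind at the same place, such as an amine, a carboxylic acid or a longer acyl chain on the nitrogen, since a single step within the scatter sets no limit on what the position accepts. Also open, as far as these compounds go, is whether the same change reads alike with fluorine elsewhere on the benzylidene rings, as compound 1 and compound 2 differ from this pair in more than one place and offer no comparison.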